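The source may hold more compounds than are shown below. What is called first, only, known or untested is meant among the compounds shown, and "the series" means these compounds.

Measured so far:
compound 1 `COc1cc(CNC(=O)/C=C/c2ccc(O)cc2)ccc1OCc1nc(C)c(C)nc1C` — 3740 nM
compound 2 `COc1cc(CNC(=O)/C=C/c2cccc(OC)c2OC)ccc1OCc1nc(C)c(C)nc1C` — 7150 nM

In a functional assay on SH-SY5Y cells (Homo sapiens) for cytotoxicity, read by MTT assay, with stated times of 24 h and 4 h (a lower number here means that less compound is needed, a higher number that more compound is needed for the effect), compound 2 gives the higher of the two numbers; its nearest neighbour is compound 1, and the step of a 1.9-fold higher number from compound 1 to compound 2 (0.28 log units; within the scatter) lies within the scatter. Compound 3 `COc1cc(CNC(=O)/C=C/c2ccc(OC)c(OC)c2OC)ccc1OCc1nc(C)c(C)nc1C` differs from compound 2 by methoxy in place of hydrogen on an aromatic carbon. Going by the values given here, the only measured step, from compound 1 to compound 2, swapped the whole ring pattern and still moved the number little, so adding one more methoxy is expected to give no step beyond the scatter: a 1.0-fold lower number from compound 2 to compound 3 (0.01 log units; within the scatter). For compound 3 the estimate is 7000 nM, within 3000 nM to 16000 nM.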

Compound 3, half-maximal effective concentration: 3840 nM
Beside the measured number, compound 3's estimate is 1.8-fold (0.26 log units) above it; low and high end bracket the measured number.
By their numbers in this assay, from the lowest: compounds 1, 3 and 2 (each within the scatter of the next).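

In this assay the step of a 1.9-fold lower number from compound 2 to compound 3 (0.27 log units; within the scatter) shows that methoxy in place of hydrogen, para to a large group, does not shift the number beyond the scatter. The wider swap to 2,3,4-trimethoxyphenyl in place of 4-hydroxyphenyl gives a 1.0-fold higher number from compound 1 to compound 3 (0.01 log units; within the scatter) and so also stays within the scatter, which means this ring has now tolerated two different patterns as well as the added methoxy. No measured evidence explains these results. On these data alone, whether an amine or a carboxylic acid at this position would move the number remains open.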